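The compounds below may be only part of what the source reports. "The series", "measured", "known", "first", "only" and "open" are said of these compounds alone.

Compound 1 `Cc1ccc(-c2csc(NC(=O)COc3ccccc3C)n2)cc1` was tested in a functional assay on Ehrlich cells (Mus musculus) for cytotoxicity, read by MTT assay, with a stated time of 48 h (on this read-out lower numbers stand for stronger inhibition and higher numbers for weaker inhibition), and gave 54400 nM. Compound 2 `Cc1ccc(-c2csc(NC(=O)COc3ccc(F)cc3F)n2)cc1` gave 14900 nM in this assay; the step of a 3.7-fold lower number from compound 1 to compound 2 (0.56 log units; beyond the scatter) came with the change (2,4-difluorophenyl in place of 2-methylphenyl on an oxygen on a saturated carbon). Compound 3 `Cc1ccccc1OCC(=O)Nc1nc(-c2ccc(Cl)cc2)cs1` gave 62300 nM in this assay, a step of a 1.1-fold higher number from compound 1 to compound 3 (0.06 log units; within the scatter) that comes with chloro in place of methyl on an aromatic carbon. Compound 4 `O=C(COc1ccc(F)cc1F)Nc1nc(-c2ccc(Cl)cc2)cs1` has not yet been measured. Among the measured compounds shown here, it differs from compound 3 by 2,4-difluorophenyl in place of 2-methylphenyl on an oxygen on a saturated carbon, which is the same change as the one from compound 1 to compound 2, made on the core of compound 3 rather than the core of compound 1; the two cores differ by chloro in place of methyl on an aromatic carbon. Because the earlier step of a 3.7-fold lower number from compound 1 to compound 2 (0.56 log units; beyond the scatter) was beyond the scatter, a similar step a 3.7-fold lower number from compound 3 to compound 4 (0.56 log units; beyond the scatter) is expected here. Compound 4 is therefore estimated at 17000 nM in this assay, between 7000 nM and 40000 nM.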

Compound 4, half-maximal inhibitory concentration: 26200 nM
For compound 4 the middle estimate is 1.5-fold (0.19 log units) below the measured one; low and high end bracket the measured number.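

In this assay, 2,4-difluorophenyl in place of 2-methylphenyl gives a 2.4-fold lower number from compound 3 to compound 4 (0.38 log units; beyond the scatter), so the change carries over to the second core with a similar size: the same change on two cores in this assay, a 3.7-fold lower number (0.56 log units; beyond the scatter) from compound 1 to compound 2 and a 2.4-fold lower number (0.38 log units; beyond the scatter) from compound 3 to compound 4, 1.5-fold (0.19 log units) apart, within the scatter of two such steps. Chloro in place of methyl gives a 1.8-fold higher number from compound 2 to compound 4 (0.25 log units; within the scatter), which stays within the scatter on this core as it did on the other: the same change on two cores in this assay, a 1.1-fold higher number (0.06 log units; within the scatter) from compound 1 to compound 3 and a 1.8-fold higher number (0.25 log units; within the scatter) from compound 2 to compound 4, 1.5-fold (0.19 log units) apart, within the scatter of two such steps. This is a single pair of cores, so it does not show that the change would carry to other cores, and it does not explain why the numbers fall.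

Still open, on these data alone, is how a phenyl ring bearing an amine or a carboxylic acid would compare with 2,4-difluorophenyl. Also open, as far as these compounds go, is what a longer chain would do in place of the saturated chain carbon.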